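Swapping thiophene for pyridine on a fused aminopyridine core

The compounds below may be only part of what the source reports. "The series", "measured", "known", "first", "only" and "open" are said of these compounds alone.

Compound 1 `Fc1ccc(-c2nn3c(NC4CCCC4)cccc3c2-c2ccsc2)cc1` — "not determined" (no result reported) in an ADME assay on Vero cells (Chlorocebus sabaeus) for cytotoxicity; on this read-out higher numbers stand for lower toxicity in this test and lower numbers for higher toxicity in this test
Compound 2 `NNc1cc(-c2c(-c3ccc(F)cc3)nn3c(NC4CCCC4)cccc23)ccn1` — 40000 nM
Compound 3 `Fc1ccc(-c2nn3c(NC4CCCC4)cccc3c2-c2ccc3[nH]ccc3c2)cc1` — 20000 nM

Compound 1 carries a thiophen-3-yl group on the aromatic carbon of the fused core, and in this assay compound 1 gives "not determined" (no result reported), so its position on the numbers shown cannot be given. Compound 4 `Fc1ccc(-c2nn3c(NC4CCCC4)cccc3c2-c2ccncc2)cc1` differs from it by one change: pyridin-4-yl in place of thiophen-3-yl on an aromatic carbon.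

Among the measured compounds shown here, one measured step concerns the group on that same aromatic carbon of the five-membered ring with two nitrogen atoms. Compound 2 gives 40000 nM in this assay, compound 3 gives 20000 nM, and the step between them is a 2.0-fold lower number from compound 2 to compound 3 (0.30 log units; within the scatter). So exchanging one aromatic group for another on that carbon, with the rest of the core kept, left the cytotoxicity within the scatter. For the measured compounds named here, that step does not involve the thiophen-3-yl or pyridin-4-yl groups themselves, and compound 1 has no number, so no step value can be written for compound 4. The expectation is that compound 4 will land near the two measured compounds, with no step beyond the scatter in this assay. Compound 4 is estimated at 25000 nM, within a range of 8000 nM to 80000 nM.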

Compound 4, half-maximal cytotoxic concentration: 20000 nM
For compound 4 the middle estimate is 1.3-fold (0.10 log units) above the measured one; measured number inside the range.
By their numbers in this assay, from the lowest: compounds 3, 4 and 2 (each within the scatter of the next).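

With compound 4, three aromatic groups on this carbon of the five-membered ring can be compared, and pyridin-4-yl in place of 1H-indol-5-yl gives no change at the digits printed from compound 3 to compound 4 (within the scatter) in this assay, so the single six-membered ring and the larger indole group read alike here. Compound 4 also separates the pyridine ring from its aminoamino group: hydrogen in place of that group gives a 2.0-fold lower number from compound 2 to compound 4 (0.30 log units; within the scatter) and shows that, among these compounds, the aminoamino group does not move the number beyond the scatter. Compound 1 has no single number, so the step from thiophen-3-yl to pyridin-4-yl cannot be read, and nothing at hand accounts for the close agreement of compounds 2, 3 and 4.

Going by these compounds, all three numbers come from aromatic groups on this carbon, so it remains open whether a non-aromatic group there, such as a piperidine, or a carboxylic acid on the pyridine ring would give a step beyond the scatter. On these data alone, the cyclopentylamino group and the 4-fluorophenyl group stay the same throughout, so what an open-chain amine or a plain phenyl group would do in those places also remains open.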